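Halogen swap on the benzamide ring of a receptor agonist

The source may hold more compounds than are shown below. What is called first, only, known or untested is meant among the compounds shown, and "the series" means these compounds.

The compounds share a core in which an amide links a sulfonamide-bearing ring to a dihalogenated phenyl ring. Compound 1 `O=C(Nc1ccc(Cl)cc1Cl)c1ccc(S(=O)(=O)Nc2ccccc2)cc1` and compound 2 `O=C(Nc1ccc(S(=O)(=O)NCc2ccccc2)cc1)c1ccc(Cl)cc1Cl` have been made, but in a functional assay on HEK293 cells for agonist activity at probable G-protein coupled receptor 27 (Homo sapiens), read by a luciferase reporter and beta-arrestin recruitment, with a stated time of 10 min (on this read-out lower numbers stand for smaller maximal responses and higher numbers for larger maximal responses), compound 1 shows "not determined" (no result reported) and compound 2 shows "not determined" (no result reported), so no number exists for either. In this assay compound 3 `O=C(Nc1ccc(S(=O)(=O)Nc2ccccc2)cc1)c1ccc(Cl)cc1Br` reaches 123%, the only number shown, and it therefore stands alone with nothing to rank it against. Compound 4 `O=C(Nc1ccc(S(=O)(=O)Nc2ccccc2)cc1)c1ccc(I)cc1F` has not yet been measured. It differs from compound 3 at one place: 2-fluoro-4-iodophenyl in place of 2-bromo-4-chlorophenyl on a carbonyl carbon. Two halogens on the same ring are exchanged for two others, while the amide, the sulfonamide and the ring itself stay as they are. Among the measured compounds shown here, no measured pair shows how such an exchange moves this read-out, so the expectation rests only on the response of compound 3 and on the small size of the change. A step of a number 8 percentage points lower from compound 3 to compound 4 (within the scatter) is expected, which lies within the usual scatter of repeated measurements, in no clear direction. Compound 4 is expected to reach about 115% in this assay, with a likely range from 80% to 145%.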

Compound 4, largest response reached (Emax), in percent of the reference or control that the assay uses: 36%
The estimate for compound 4 lay 79 percentage points above the measured number; measured number outside the range, below it.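

Within this assay the exchange of 2-bromo-4-chlorophenyl for 2-fluoro-4-iodophenyl on the carbonyl carbon gives a number 87 percentage points lower from compound 3 to compound 4 (beyond the scatter) and so shows that the maximal response depends strongly on which halogens this ring carries. The change looks small on paper, since both groups have the same number of heavy atoms and neither has a hydrogen-bond donor, a hydrogen-bond acceptor or a net charge, yet these shared counts do not keep the response in place. Nothing available points to the reason for this loss of response.

Both halogens change in this single step, so the compounds shown cannot tell whether the exchange of bromine for fluorine, the exchange of chlorine for iodine, or the two together account for it, and steps involving compound 1 or compound 2 cannot be read without a number for either. Also open, from the compounds shown here alone, is how the response would change with only one of the two halogens exchanged, or with a methoxy group or an amine in place of a halogen on this ring.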